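Chloro to methoxy on the pyridine amide: compound 4

The source may report more compounds than this note shows. Statements on the series, on what has been measured and on what is new or still open speak of the compounds shown alone.

Measured compounds and their values in a functional assay on WM 266-4 cells (Homo sapiens) for antiproliferative activity, read by MTT assay, with a stated time of 48 h; on this read-out higher numbers stand for weaker inhibition and lower numbers for stronger inhibition:
compound 1, `Cc1ccc(-c2cc(NC(=O)c3cccnc3Cl)n[nH]2)cc1`, gives 5350 nM;
compound 2, `COc1ncccc1C(=O)Nc1cc(-c2ccc(C)cc2)[nH]n1`, gives 7760 nM;
compound 3, `O=C(Nc1cc(-c2ccc(Br)cc2)[nH]n1)c1ccc(Cl)nc1`, gives 7470 nM.

Compound 1 and compound 2 differ in one place, (methoxy in place of chloro on an aromatic carbon), and the step is a 1.5-fold higher number from compound 1 to compound 2 (0.16 log units; within the scatter). Compound 3 carries a different core from compound 1; the difference between the two cores is not broken down here. Compound 3 and compound 2 sit within the scatter of each other, as do compound 3 and compound 1.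

Compound 4, `COc1ccc(C(=O)Nc2cc(-c3ccc(Br)cc3)[nH]n2)cn1`, has not yet been measured in this assay. It differs from compound 3 by methoxy in place of chloro on an aromatic carbon. This is the same kind of change as that from compound 1 to compound 2, but not the same: in the first pair the place is ortho to a large group, whereas in compound 4 it is para to a large group.

The expected step, a 1.4-fold higher number from compound 3 to compound 4 (0.15 log units; within the scatter), rests on the step from compound 1 to compound 2 being a 1.5-fold higher number from compound 1 to compound 2 (0.16 log units; within the scatter), taken as a rough guide for this assay. Because compound 3 gives 7470 nM, compound 4 is estimated at 10500 nM, with a range from 5000 nM to 22000 nM expected.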

Compound 4, half-maximal inhibitory concentration: 9120 nM
For compound 4 the middle estimate is 1.2-fold (0.06 log units) above the measured one; measured number inside the range.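

In this assay, putting methoxy in place of chloro on the ring of the amide gives a 1.2-fold higher number from compound 3 to compound 4 (0.09 log units; within the scatter), so on this core the change cannot be told apart from the ordinary spread of repeated measurements. Set beside the earlier pair, the swap looks alike on both cores, with neither step standing out from the scatter and the two steps not distinguishable from each other: the same change on two cores in this assay, a 1.5-fold higher number (0.16 log units; within the scatter) from compound 1 to compound 2 and a 1.2-fold higher number (0.09 log units; within the scatter) from compound 3 to compound 4, 1.2-fold (0.07 log units) apart, within the scatter of two such steps. Within the data shown here, this shows only that in these two pairs the swap carried over without a readable change in the number; it does not show that methoxy and chloro are interchangeable in general, since two pairs are few, the group sits at a different place on the ring in each pair, and a real effect smaller than the scatter would stay hidden.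

The compounds shown hold only chloro and methoxy at these places, so what an amine, a hydroxyl or a longer chain such as ethoxy would do there remains open. Also open, on these data alone, is whether the swap would stay this small on a core carrying something other than methyl or bromo at the far end, for example a carboxylic acid.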